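The source may report more compounds than this note shows. Statements on the series, on what has been measured and on what is new or still open speak of the compounds shown alone.

Series notes, thiourea esters bearing a furan substituent.

Two members of the series have been measured in an assay on membranes from HEK293 cells for displacement of a labelled ligand from adenosine receptor A2b (Homo sapiens), read by scintillation counting, with a stated time of 30 min, tested at 1 uM; on this read-out higher numbers stand for more inhibition at the one concentration tested (going by the name of the read-out) and lower numbers for less inhibition. Compound 1, `CC1=C(C(=O)OC(C)(C)C)C(c2ccco2)NC(=S)N1`, gives 9% in this assay. Compound 2, `COC(=O)C1=C(C)NC(=S)NC1c1ccoc1`, gives 48% in this assay, the higher of the two numbers shown so far, with compound 1 falling well beyond the scatter below it. Within the data shown here, compound 1 and compound 2 differ in two places at once, so the two values say only that the pair sits far apart, not which change carries the gap.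

The next compound to be tested is compound 3, `CC1=C(C(=O)OCC(C)C)C(c2ccoc2)NC(=S)N1`. Relative to compound 2 the change is isopropyl in place of hydrogen on a saturated chain carbon bound to an oxygen next to a carbonyl group. Among the measured compounds shown here, no measured step of this kind exists, so the size of the step has to be guessed. The only other ester in hand, the bulky one of compound 1, sits at the low end of the numbers shown, but compound 1 also carries its furan differently, so that value cannot be read as a step in ester size alone. A modest loss from compound 2 to compound 3 is expected, a number 16 percentage points lower from compound 2 to compound 3 (beyond the scatter), of a size that may or may not exceed the scatter. On that basis compound 3 is estimated at 32% in this assay, with a range from 10% to 55%.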

Compound 3, a percentage reported as inhibition, at one concentration (the size of the read-out at that concentration, not a potency): 1%
For compound 3 the middle estimate is 31 percentage points above the measured one; the whole stated range lies above it.
By their numbers in this assay, from the lowest: compounds 3 and 1 (each within the scatter of the next); then compound 2.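

In this assay the series now has its first step in a single place: isopropyl in place of hydrogen on a saturated chain carbon bound to an oxygen next to a carbonyl group gives a change of a number 47 percentage points lower from compound 2 to compound 3 (beyond the scatter), so that methoxy to isobutoxy alone is enough to take away nearly all of the inhibition seen at the one concentration tested. The pair of compound 1 and compound 2 could not show this, since those two differ in two places at once; this place is now known to matter strongly on its own, at least for the core and furan attachment of compound 2. Nothing at hand gives a reason for the size of this step.

Open is whether the loss follows chain length, branching or something else, since only the two ends of the change are shown: an ethoxy or unbranched butoxy group at this place would help to separate these. Also open, as far as these compounds go, are a carboxylic acid or an amide in place of the ester, and whether the same step would appear with the furan attached as in compound 1.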